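Cyanopyrrolidine amides: amide swap toward an ethylamino carboxamide

The source may hold more compounds than are shown below. What is called first, only, known or untested is meant among the compounds shown, and "the series" means these compounds.

Measured so far:
compound 1 `N#C[C@@H]1CCCN1C(=O)[C@@H]1C[C@H](C(=O)N2CCCCCCC2)CN1` — "not determined" (no result reported)
compound 2 `C[C@@H]1N[C@H](C(=O)N2CCC[C@H]2C#N)C[C@@H]1C(=O)N1CCCC1` — 88%

Within the data shown here, in an assay on the whole organism (plasma, strain Sprague-Dawley) for inhibition of Dipeptidyl peptidase 4 (Rattus norvegicus), with a stated time of 10 h, at a dose of 1 mg/kg by the oral route (on this read-out higher numbers stand for more inhibition at the one dose given (going by the name of the read-out) and lower numbers for less inhibition), compound 1 stands without a number; compound 2 is the only compound of the series with a result there, and compound 2 gives 88%. Compound 3 `CCNC(=O)[C@@H]1CN[C@H](C(=O)N2CCC[C@H]2C#N)C1` differs from compound 1 by a group of 3 heavy atoms (2 carbon, 1 nitrogen; no ring) in place of a group of 8 heavy atoms (7 carbon, 1 nitrogen; one eight-membered non-aromatic ring with 1 hetero atom), on a carbonyl carbon.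

Among the measured compounds shown here, no step between measured compounds is known, so the effect of this change is not anchored by data. Both compounds keep the nitrile-bearing pyrrolidine amide, and the change sits only at the second carbonyl. The step from compound 1 to compound 3 is expected to be small, within scatter or a modest loss at most, with no firm direction. With compound 2 reaching 88% under the same conditions, compound 3 is expected near 70%, with a plausible range from 40% to 92%.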

Compound 3, a percentage reported as inhibition, in the whole organism at one dose (the size of the read-out at that dose, not a potency): 19%
Compound 3: the middle estimate sits 51 percentage points above what was measured, outside the stated range (below it).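

No step can be read between compound 1 and compound 3 in this assay. The compounds shown leave open how much of the result for compound 3 belongs to the ethylamino group on the carbonyl carbon. No measurement at hand bears on this result.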